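A few compounds are considered here, and "the series" means these few. Any claim that something is new, unique, unknown or untested is made for them only; others in the source may bear on it.

Working notes on the series. In an ADME assay on HCT-116 cells (Homo sapiens) for antiproliferative activity (on this read-out higher numbers stand for weaker inhibition and lower numbers for stronger inhibition), compound 1 (`COc1ccc(C(N)=O)cc1/C=C/c1ccc(Cl)cc1`) gives 7100 nM, the lower of the two true numbers in hand. Compound 2 (`COc1ccc(/C=C/c2cc(C(N)=O)ccc2OC)cc1`) gives 19000 nM. Compound 3 (`COc1ccc(C(N)=O)cc1/C=C/c1ccc(Cl)cc1F`) is reported only as a limit, > 10000 nM.

The next step leads to compound 4 (`NC(=O)c1ccc(OCCOCCO)c(/C=C/c2ccc(Cl)cc2)c1`). The change is (2-hydroxyethoxy)methyl in place of hydrogen on a saturated chain carbon bound to an oxygen on an aromatic ring. Read one bond further out, methoxy becomes 2-(2-hydroxyethoxy)ethoxy.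

Two measured steps start from compound 1. Methoxy in place of chloro on an aromatic carbon gives a 2.7-fold higher number from compound 1 to compound 2 (0.43 log units; beyond the scatter). Fluoro in place of hydrogen on an aromatic carbon gives an at least 1.4-fold higher number from compound 1 to compound 3 (0.14 log units; that floor lies within the scatter). Neither change is made at the saturated chain carbon in question, so both bear on compound 4 only indirectly. They show the size of single changes on the shared core in this assay, and neither gives a lower number than compound 1.

With so little to go on, a small upward move is the working expectation, no larger than the modest rise to compound 2 at 19000 nM and possibly within the scatter. The expected step is a 1.5-fold higher number from compound 1 to compound 4 (0.19 log units; within the scatter). Compound 4 is estimated at 11000 nM, with an expected range of 4000 nM to 30000 nM.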

Compound 4, half-maximal inhibitory concentration: 38000 nM
Beside the measured number, compound 4's estimate is 3.5-fold (0.54 log units) below it, and the stated range ends below it.
By their numbers in this assay, from the lowest: compound 1; then compounds 2 and 4 (each within the scatter of the next).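

In this assay the saturated chain carbon bound to an oxygen on an aromatic ring now has a measured step of its own: (2-hydroxyethoxy)methyl in place of hydrogen there gives a 5.4-fold higher number from compound 1 to compound 4 (0.73 log units; beyond the scatter) and the methoxy of compound 1 therefore does not become 2-(2-hydroxyethoxy)ethoxy without a loss on this read-out. Among these compounds, the earlier steps were changes made elsewhere on the shared core, so this is the first reading at this position, and it also fails to give a lower number than compound 1. Nothing measured in the compounds shown says why the number rises at this position.

One substituent at this carbon cannot separate the length of the chain from its terminal hydroxyl, so a shorter 2-hydroxyethoxy group, a longer ether chain without the hydroxyl, or a chain ending in an amine or a carboxylic acid would each be informative. On these data alone, whether the same change behaves alike on a core carrying other groups also stays open.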